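The source may hold more compounds than are shown below. What is called first, only, known or untested is meant among the compounds shown, and "the series" means these compounds.

Measured in an ADME assay on Vero 76 cells (Chlorocebus sabaeus) for cytotoxicity, read by MTT assay, with a stated time of 96 h; on this read-out lower numbers stand for higher toxicity in this test and higher numbers for lower toxicity in this test:
compound 1, `Cc1ccccc1C1CC(c2ccc(OCc3ccccc3)cc2)=NN1c1ccc(S(N)(=O)=O)cc1`: 100000 nM
compound 3, `Cc1ccccc1C1CC(c2ccc(Oc3ccccc3)cc2)=NN1c1ccc(S(N)(=O)=O)cc1`: 90000 nM
Compound 2, `NS(=O)(=O)c1ccc(N2N=C(c3ccc(OCc4ccccc4)cc3)CC2c2ccccc2F)cc1`, reaches only the assay limit of > 100000 nM in this assay.

The change from compound 1 to compound 2 is fluoro in place of methyl on an aromatic carbon, and it gives a number no lower from compound 1 to compound 2 (the limit leaves the size open); the value of compound 2 sits at the limit of > 100000 nM in this assay, at which 1 of the 3 values shown sits. The two cores differ by phenyl in place of benzyl on an oxygen on an aromatic ring, which gives a 1.1-fold lower number from compound 1 to compound 3 (0.05 log units; within the scatter). Compound 4, `NS(=O)(=O)c1ccc(N2N=C(c3ccc(Oc4ccccc4)cc3)CC2c2ccccc2F)cc1`, is not yet measured in this assay; it differs from compound 3 by fluoro in place of methyl on an aromatic carbon, the same change as that between compound 1 and compound 2, at a place described in the same words. Compound 3 gives 90000 nM. The step from compound 3 to compound 4 is expected to be a 1.2-fold higher number from compound 3 to compound 4 (0.09 log units; within the scatter), because the earlier step was a number no lower from compound 1 to compound 2 (the limit leaves the size open). Compound 4 is therefore estimated at 110000 nM in this assay, with a fair chance that only a limit is reported.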

Compound 4, half-maximal cytotoxic concentration: 96000 nM
Estimate against measurement, compound 4: 1.1-fold (0.06 log units) above; low and high end bracket the measured number.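

Fluoro in place of methyl on an aromatic carbon gives a 1.1-fold higher number from compound 3 to compound 4 (0.03 log units; within the scatter), and the earlier instance of this change can be set beside it only through a limit: the same change on two cores in this assay, a number no lower (the limit leaves the size open) from compound 1 to compound 2 and a 1.1-fold higher number (0.03 log units; within the scatter) from compound 3 to compound 4; the limit leaves it open whether they differ. Phenyl in place of benzyl on an oxygen on an aromatic ring gives an at least 1.0-fold lower number from compound 2 to compound 4 (0.01 log units; that floor lies within the scatter), and this comparison also rests on a limit: the same change on two cores in this assay, a 1.1-fold lower number (0.05 log units; within the scatter) from compound 1 to compound 3 and an at least 1.0-fold lower number (0.01 log units; that floor lies within the scatter) from compound 2 to compound 4; the limit leaves it open whether they differ. The readable steps show no change beyond the scatter on these cores, but they do not show that either change has the same size on another core.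

Open in this assay is how a chloro, a methoxy or an amine on that aromatic carbon would read. Also open, going by these compounds, is the true size of any step involving compound 2, whose value is a limit.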